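The source may hold more compounds than are shown below. What is called first, only, known or untested is meant among the compounds shown, and "the series" means these compounds.

Within the data shown here, compound 1, with the structure `CC(C)Oc1ccc(CNC(=O)c2ccc(C(C)(C)C)cc2)cc1`, is the stronger of the two compounds measured so far: in an assay on HeLa cells with Bile acid receptor (Homo sapiens) as the target, read by a luciferase reporter, with a stated time of 24 h (on this read-out lower numbers stand for an effect already at smaller amounts and higher numbers for an effect only at larger amounts of compound), compound 1 gives 170 nM, the lowest of the two numbers. Its neighbour is compound 2, with the structure `C[S+]([O-])c1ccc(CNC(=O)c2ccc(C(C)(C)C)cc2)cc1`, which in this assay gives 1300 nM. Among the measured compounds shown here, the only step available, from compound 1 to compound 2, is a 7.6-fold higher number from compound 1 to compound 2 (0.88 log units; beyond the scatter), so swapping the isopropoxy on the outer ring for a small sulfur-bearing group costs a clear amount of potency.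

Compound 3, with the structure `CC(C)(C)c1ccc(C(=O)NCc2ccc(S(C)(=O)=O)cc2)cc1`, has not been measured yet. It differs from compound 1 in one place: methylsulfonyl in place of isopropoxy on an aromatic carbon. The measured step from compound 1 to compound 2 bears directly on this change, since both replace the isopropoxy by a small sulfur-centred group on the same aromatic carbon, and it pointed to a loss in this assay well beyond the scatter. A step of similar size and the same direction is therefore expected here, written as an 8.8-fold higher number from compound 1 to compound 3 (0.95 log units; beyond the scatter). For compound 3 the estimated value in this assay is 1500 nM, with a likely range from 500 nM to 5000 nM.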

Compound 3, half-maximal effective concentration: 3800 nM
The estimate for compound 3 lay 2.5-fold (0.40 log units) below the measured number; measured number inside the range.
By their numbers in this assay, from the lowest: compound 1; then compound 2; then compound 3.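

In this assay there is a 22-fold higher number from compound 1 to compound 3 (1.35 log units; beyond the scatter), the largest step seen at this position, and it comes without any change in size as counted by heavy atoms, since isopropoxy and methylsulfonyl each hold 4. Sulfur-bearing groups at this position are also not interchangeable: there is a 2.9-fold higher number from compound 2 to compound 3 (0.47 log units; beyond the scatter), and here the group with more heavy atoms goes with the higher number, so among these three compounds the heavy-atom count alone does not set the order. No measurement at hand explains why these groups differ in this way.

The three compounds leave open whether the loss is tied to sulfur itself or would also appear with a carbon-centred group such as a carboxylic acid or a nitrile on the same aromatic carbon. They also leave open how far the isopropoxy can be varied while keeping the low number of compound 1, for instance by a methoxy, a longer alkoxy chain or an amine in its place.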